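The compounds below may be only part of what the source reports. "The series", "measured", "known", "first", "only" and "open" are said of these compounds alone.

Measured so far:
compound 1 `CCCc1ccc(C#Cc2cc3cn([C@H]4C[C@H](O)[C@@H](CO)O4)c(=O)nc3o2)cc1`: 87000 nM
compound 2 `O=c1nc2oc(C#Cc3ccccc3)cc2cn1[C@H]1C[C@H](O)[C@@H](CO)O1`: > 570000 nM
compound 3 `CCCc1ccc(CCc2cc3cn([C@H]4C[C@H](O)[C@@H](CO)O4)c(=O)nc3o2)cc1`: >= 130000 nM

In an ADME assay on HEL cells (Homo sapiens) for cytotoxicity, with a stated time of 3 days (a lower number here means that less compound is tolerated, a higher number that more compound is tolerated), compound 1 gives 87000 nM. For compound 2 the value > 570000 nM is a limit of the assay, not a number. For compound 3 the value >= 130000 nM is likewise a limit. The change hydrogen in place of propyl on an aromatic carbon gives an at least 6.5-fold higher number from compound 1 to compound 2 (0.81 log units; beyond the scatter). Compound 4 `O=c1nc2oc(CCc3ccccc3)cc2cn1[C@H]1C[C@H](O)[C@@H](CO)O1` is not yet measured; it differs from compound 3 by hydrogen in place of propyl on an aromatic carbon, the same change at the same place, occurring twice among these compounds. The difference between the core of compound 3 and that of compound 1 is not broken down here. Compound 3 sits at the limit of >= 130000 nM in this assay, at which 1 of the 3 values shown sits. Compound 2 sits at the limit of > 570000 nM in this assay, at which 1 of the 3 values shown sits. Compound 4 is therefore expected to be reported as a limit as well. The step that the limit leaves unreadable from compound 3 to compound 4 is expected to resemble the measured one in direction. Compound 4 is expected at 500000 nM, between 200000 nM and 1500000 nM.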

Compound 4, minimum cytotoxic concentration: > 560000 nM
Compound 4: no number, only a limit; the forecaster's own chance of this, stated with the estimate: 70%; middle value at least 1.1-fold (0.04 log units) from the limit.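

The steps from compound 3 to compound 4 and from compound 2 to compound 4 cannot be read: all three compounds stand only as limits. Left open is whether hydrogen in place of propyl changes the number in the compound 3 and compound 4 pair, and how phenethyl compares with 2-phenylethynyl.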